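Ethynyl in place of phenyl: notes on compound 4

A few compounds are considered here, and "the series" means these few. Any claim that something is new, unique, unknown or untested is made for them only; others in the source may bear on it.

Compound 3 `CSc1ncnc2c1c(-c1ccccc1)cn2[C@@H]1O[C@H](CO)[C@@H](O)[C@H]1O` gives > 20000 nM in a functional assay on CEM-DNR-bulk cells (Homo sapiens), read by MTT assay, with a stated time of 72 h (a higher number here means a weaker inhibitor, a lower number a stronger inhibitor), which is a limit of the assay and not a number. Compound 2 `CSc1ncnc2c1c(-c1cccs1)cn2[C@@H]1O[C@H](CO)[C@@H](O)[C@H]1O` gives > 20000 nM in this assay, which is also a limit. For the measured compounds named here, the only measured step, a step that the two limits leave unreadable from compound 2 to compound 3, offers no size to carry forward. The picture so far is dominated by the limit of > 20000 nM in this assay, at which 2 of the 3 values shown sit.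

Compound 4 `C#Cc1cn([C@@H]2O[C@H](CO)[C@@H](O)[C@H]2O)c2ncnc(SC)c12`, not yet measured, departs from compound 3 by ethynyl in place of phenyl on an aromatic carbon. Going by the values given here, the only numerical guide is compound 1 `C#Cc1cn([C@@H]2O[C@H](CO)[C@@H](O)[C@H]2O)c2ncnc(OC)c12`, which also carries ethynyl and gives 3490 nM in this assay. On the strength of that value, a move towards stronger inhibition is expected, and a reading inside the measurable range is more likely than another limit. The expected step is an at least 6.6-fold lower number from compound 3 to compound 4 (0.82 log units; beyond the scatter). Its size remains uncertain, since compound 3 has no exact value. For compound 4, the estimated value is 3000 nM, with an expected range of 600 nM to 15000 nM.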

Compound 4, half-maximal inhibitory concentration: 110 nM
The estimate for compound 4 lay 27-fold (1.44 log units) above the measured number, and the stated range ends above it.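

In this assay, ethynyl in place of phenyl on this aromatic carbon gives an at least 180-fold lower number from compound 3 to compound 4 (2.25 log units; beyond the scatter), and ethynyl in place of thiophen-2-yl gives an at least 180-fold lower number from compound 2 to compound 4 (2.25 log units; beyond the scatter). Both steps start from a limit of the assay and not a number: the limit of > 20000 nM in this assay, at which 2 of the 4 values shown sit. The other substituent on the shared core also matters: with ethynyl held fixed, methylsulfanyl in place of methoxy gives a 32-fold lower number from compound 1 to compound 4 (1.50 log units; beyond the scatter), so the ethynyl effect cannot be read from compound 1 alone.

As far as these compounds go, whether methyl or a nitrile on this carbon would also give a reading inside the measurable range stays open. Also open, from the compounds shown here alone, is whether an amine in place of methylsulfanyl would keep the value of compound 4 at 110 nM.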